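This account rests on a few compounds, and the source may have more. Where it says the series, first, only, none or still open, it means among the compounds named here.

In a functional assay on MDA-MB-231 cells (Homo sapiens) for cytotoxicity, with a stated time of 48 h (a higher number here means a weaker inhibitor, a lower number a stronger inhibitor), compound 2 (`COc1cc(OC)c(C(=O)/C=C/c2ccccc2)c(OC)c1`) gives 12900 nM and compound 1 (`COc1cc(OC)c(C(=O)/C=C/c2ccccc2SC)c(OC)c1`) gives 9900 nM, so these two values lie within the scatter of each other. Compound 3 (`COc1cc(OC)c(C(=O)/C=C/c2ccc(Cl)cc2)c(OC)c1`) has not yet been measured. It differs from compound 2 by a single change, (chloro in place of hydrogen on an aromatic carbon), which is chloro in place of hydrogen on an aromatic carbon. Going by the values given here, only one measured step bears on this change: a 1.3-fold higher number from compound 1 to compound 2 (0.11 log units; within the scatter). That step also concerns a group on an aromatic carbon, but it involves methylsulfanyl rather than chloro, so it is only a loose guide. On that evidence, no shift beyond the scatter is expected in this assay. The estimate corresponds to an expected step of a 1.3-fold lower number from compound 2 to compound 3 (0.11 log units; within the scatter). For compound 3 the expected value is 10000 nM, with an estimated range of 4500 nM to 22000 nM.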

Compound 3, half-maximal inhibitory concentration: 8200 nM
For compound 3 the middle estimate is 1.2-fold (0.09 log units) above the measured one, within the range that was stated.
By their numbers in this assay, from the lowest: compounds 3, 1 and 2 (each within the scatter of the next).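

In this assay, going by these compounds alone, the single change from hydrogen to chloro, on an aromatic carbon para to a large group, gives a 1.6-fold lower number from compound 2 to compound 3 (0.20 log units; within the scatter) and so adds a second substituent to the methylsulfanyl group as one that leaves the number within the scatter of the unsubstituted phenyl compound. Exchanging the substituted ring outright, 4-chlorophenyl for the methylsulfanyl-bearing phenyl, gives a 1.2-fold lower number from compound 1 to compound 3 (0.08 log units; within the scatter) and likewise separates nothing, so neither group stands apart from the other at this level of resolution. No measurement offered here accounts for this result.

From the compounds shown here alone, whether an amine or a carboxylic acid at this para position would carry the number beyond the scatter remains open. With every step among these compounds within the scatter, they also do not show which changes to this ring, if any, matter in this assay.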